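Low-exposure compound 3 and its carbamate analogue

The source may report more compounds than this note shows. Statements on the series, on what has been measured and on what is new or still open speak of the compounds shown alone.

Values from an ADME assay on the whole organism (plasma, Rattus norvegicus, strain Sprague-Dawley) for pharmacokinetics, read by LC-MS, with a stated time of 4 h, at a dose of 15 mg/kg by the intraduodenal route (on this read-out higher numbers stand for higher exposure at the dose given and lower numbers for lower exposure), are as follows
compound 1 `C=C[C@@H]1C[C@]1(NC(=O)[C@@H]1C[C@@H](Oc2nccc3cc(OC)ccc23)CN1C(=O)[C@@H](NC(=O)N[C@H](C(=O)OC(C)(C)C)C(C)(C)C)C(C)(C)C)C(=O)NS(=O)(=O)C1CC1` gives 632 ng.h/mL 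
compound 2 `C=C[C@@H]1C[C@]1(NC(=O)[C@@H]1C[C@@H](Oc2nccc3cc(OC)ccc23)CN1C(=O)[C@@H](NC(=O)N[C@H](C(=O)N1CCN(c2ncccn2)CC1)C(C)(C)C)C(C)(C)C)C(=O)NS(=O)(=O)C1CC1` gives 1630 ng.h/mL 
compound 3 `C=C[C@@H]1C[C@]1(NC(=O)[C@@H]1C[C@@H](Oc2cc(-c3ccccc3)nc3cc(OC)ccc23)CN1C(=O)[C@@H](NC(=O)NC(C)(C)C)C(C)(C)C)C(=O)NS(=O)(=O)C1CC1` gives 17 ng.h/mL 

Compound 3 stands lowest of the three, well beyond the scatter from both others. Compound 4 `C=C[C@@H]1C[C@]1(NC(=O)[C@@H]1C[C@@H](Oc2cc(-c3ccccc3)nc3cc(OC)ccc23)CN1C(=O)[C@@H](OC(=O)NC1CCCC1)C(C)(C)C)C(=O)NS(=O)(=O)C1CC1` differs from compound 3 as follows (cyclopentylcarbamoyl)oxy in place of ((tert-butyl)carbamoyl)amino on a saturated chain carbon bound to a carbonyl carbon and a saturated chain carbon and keeps the rest of the structure. For the measured compounds named here, no measured step covers this change. The only one, a 2.6-fold higher number from compound 1 to compound 2 (0.41 log units; beyond the scatter), is modest, replaces tert-butoxy instead and so bears only loosely. A modest rise of similar size in this assay is therefore expected, with low confidence. The expected step is a 2.4-fold higher number from compound 3 to compound 4 (0.37 log units; beyond the scatter) with wide uncertainty. The estimate for compound 4 is 40 ng.h/mL with an expected range from 10 ng.h/mL to 160 ng.h/mL for now.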

Compound 4, area under the concentration-time curve: 95 ng.h/mL
For compound 4 the middle estimate is 2.4-fold (0.38 log units) below the measured one, and the stated range covers the measured number.
By their numbers in this assay, from the lowest: compound 3; then compound 4; then compound 1; then compound 2.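

In this assay, (cyclopentylcarbamoyl)oxy in place of ((tert-butyl)carbamoyl)amino gives a 5.6-fold higher number from compound 3 to compound 4 (0.75 log units; beyond the scatter), showing that exposure responds to the group at this place on the saturated chain carbon. The change swaps a nitrogen for an oxygen and tert-butyl for cyclopentyl at once, so the step belongs to the pair of changes, not to either alone. Nothing at hand accounts for the rise. Which of the two changes carries the step stays open. A (tert-butylcarbamoyl)oxy or a (cyclopentylcarbamoyl)amino group at this place would separate them.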